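A few compounds are considered here, and "the series" means these few. Any claim that something is new, unique, unknown or untested is made for them only; others in the source may bear on it.

In a functional assay on BT-474 cells (Homo sapiens) for inhibition, read by CellTiter-Glo, with a stated time of 72 h (on this read-out lower numbers stand for stronger inhibition and higher numbers for weaker inhibition), compound 1 `Cc1cc(Nc2ncnc3cc(O)c(NC(=O)/C=C/[C@H]4CCCN4C)cc23)ccc1Oc1ccn2ncnc2c1` gives 2.4 nM and compound 2 `Cc1cc(Nc2ncnc3cc(O)c(NC(=O)/C=C/[C@H]4CCCN4C)cc23)ccc1Oc1cc2nccn2cn1` gives 5.59 nM, so compound 2 holds the higher of the two numbers and is the weaker of this pair. The next change leads to compound 3 `Cc1cc(Nc2ncnc3cc(O)c(NC(=O)/C=C/[C@H]4CCCN4C)cc23)ccc1Oc1cnn2cnnc2c1`: a group of 9 heavy atoms (5 carbon, 4 nitrogen; one five-membered aromatic ring with 3 hetero atoms, one six-membered aromatic ring with 2 hetero atoms) in place of a group of 9 heavy atoms (6 carbon, 3 nitrogen; one five-membered aromatic ring with 2 hetero atoms, one six-membered aromatic ring with 2 hetero atoms), on an oxygen on an aromatic ring. It falls on an oxygen on an aromatic ring, the same place at which compound 1 and compound 2 differ.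

For the measured compounds named here, only one measured step bears on it: a 2.3-fold higher number from compound 1 to compound 2 (0.37 log units; beyond the scatter). That step is modest, and it also exchanges one group of 9 heavy atoms for another. Going by the values given here, no measured compound carries the entering group, and a single step gives no firm direction. A step of similar modest size is therefore expected in this assay, tentatively towards a higher number, although a result within the scatter of compound 2 would not be surprising. The estimate corresponds to an expected 1.4-fold higher number from compound 2 to compound 3 (0.16 log units; within the scatter). For compound 3 the estimated value is 8 nM, with an expected range from 3 nM to 22 nM.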

Compound 3, half-maximal inhibitory concentration: 20.8 nM
Estimate against measurement, compound 3: 2.6-fold (0.41 log units) below; measured number inside the range.
By their numbers in this assay, from the lowest: compound 1; then compound 2; then compound 3.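

In this assay, the exchange on the oxygen on an aromatic ring gives a 3.7-fold higher number from compound 2 to compound 3 (0.57 log units; beyond the scatter), a second step in the same direction as the first and one that widens the spread across the series to an 8.7-fold higher number from compound 1 to compound 3 (0.94 log units; beyond the scatter). For the compounds shown here, the position therefore responds repeatedly to exchanges among groups of 9 heavy atoms, and the step to the group with 5 carbon and 4 nitrogen atoms is the one that separates compound 3 from both others, although the nitrogen count alone does not order the series, since compound 1 and compound 2 both carry groups with 6 carbon and 3 nitrogen atoms and still differ beyond the scatter. No available evidence accounts for these differences.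

Open, as far as these compounds go, is how a plain phenyl or a single pyridine ring on the same oxygen would compare with these fused groups of 9 heavy atoms. Also open, from the compounds shown here alone, is whether the order of the three groups would hold on a core carrying a methoxy group in place of the hydroxyl.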